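The compounds below may be only part of what the source reports. "The series", "measured", "known", "first", "only" and "open" are said of these compounds alone.

Measured so far in an ADME assay on HCT-116 cells (Homo sapiens) for cytotoxicity, read by CellTiter-Glo, with a stated time of 72 h; a lower number here means a stronger inhibitor, a higher number a weaker inhibitor:
compound 1 `Cc1cc(C)c(S(=O)(=O)N2CCC(N3CCC(CCO)CC3)CC2)c(C)c1`: > 5000 nM
compound 2 `Cc1ccc(C2CCN(S(=O)(=O)c3c(C)cc(C)cc3C)CC2)cc1`: > 5000 nM
compound 3 `Cc1cc(C)c(S(=O)(=O)N2CCC(N3CC(C)CC(C)C3)CC2)c(C)c1`: > 5000 nM

Each entry is a limit of the assay and not a number. Compound 3 gives only the limit > 5000 nM. The other two entries share it, so the series offers the limit of > 5000 nM in this assay, at which 3 of the 3 values shown sit, and no ranking.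

The next compound is compound 4 `Cc1cc(C)c(S(=O)(=O)N2CCC(N3CCCCC3)CC2)c(C)c1`. The change from compound 3 is piperidin-1-yl in place of 3,5-dimethylpiperidin-1-yl on a saturated ring carbon. It replaces 3,5-dimethylpiperidin-1-yl with piperidin-1-yl on a saturated ring carbon.

Two measured steps alter the same place: a step that the two limits leave unreadable from compound 1 to compound 3 and a step that the two limits leave unreadable from compound 2 to compound 3. Neither has a readable size, so neither shows how far a change here can move this assay. Across these three different groups, no number has appeared.

A shift beyond the scatter is therefore not expected, and a further limit is the likeliest report. The estimated change is a step that the limit leaves unreadable from compound 3 to compound 4. For compound 4 the estimate is 8000 nM, with an expected range of 3000 nM to 20000 nM.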

Compound 4, half-maximal inhibitory concentration: > 5000 nM
Compound 4 was reported as a limit; the forecaster's own chance of this, stated with the estimate: 85%; the middle value lies beyond the limit too.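

In this assay, among these compounds, compound 4 gives > 5000 nM, a limit of the assay and not a number, so no step from compound 1, compound 2 or compound 3 to compound 4 can be read. Whether any group at this place gives a measurable value stays open, since the series offers only one limit: the limit of > 5000 nM in this assay, at which 4 of the 4 values shown sit.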